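This account rests on a few compounds, and the source may have more. Where it says the series, first, only, none or still open, it means among the compounds named here.

Compound 3, `COC(=O)C1=C(C)NC(=O)N(C(=O)NCCCN2CCN(c3cccc(Cl)c3)CC2)C1c1ccc(F)c(F)c1`, sits at the top of the three numbers in hand. In an assay on liver for binding affinity to Alpha-1A adrenergic receptor (Homo sapiens), using microsomes (a lower number here means a stronger inhibitor, a higher number a weaker inhibitor), compound 3 gives 0.7 nM. Compound 1, `COC(=O)C1=C(C)NC(=O)N(C(=O)NCCCN2CCN(c3ccccc3OC)CC2)C1c1ccc(F)c(F)c1`, gives 0.1 nM, and compound 2, `CCOc1ccccc1N1CCN(CCCNC(=O)N2C(=O)NC(C)=C(C(=O)OC)C2c2ccc(F)c(F)c2)CC1`, gives 0.1 nM. The step of a 7.0-fold higher number from compound 1 to compound 3 (0.85 log units; beyond the scatter) and the step of a 7.0-fold higher number from compound 2 to compound 3 (0.85 log units; beyond the scatter) both replace the aryl group on the amine nitrogen in a ring, while the step of no change at the digits printed from compound 1 to compound 2 (within the scatter) lies within the scatter.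

Compound 4, `COC(=O)C1=C(C)NC(=O)N(C(=O)NCCCN2CCN(c3cccc([N+](=O)[O-])c3)CC2)C1c1ccc(F)c(F)c1`, differs from compound 3 by nitro in place of chloro on an aromatic carbon. Within the data shown here, no measured step swaps one substituent for another on the same aryl ring; the two steps that touch that aryl group were modest in size, and they say nothing about the direction of a change from chloro to nitro. The expectation for compound 4 in this assay is therefore a number close to that of compound 3, with a wide range. For compound 4 the estimate is 1 nM, between 0.3 nM and 3.5 nM. The expected step is a 1.4-fold higher number from compound 3 to compound 4 (0.15 log units; within the scatter).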

Compound 4, inhibition constant: 12 nM
Beside the measured number, compound 4's estimate is 12-fold (1.08 log units) below it, outside the stated range (above it).
By their numbers in this assay, from the lowest: compounds 1 and 2 (each within the scatter of the next); then compound 3; then compound 4.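

The earlier steps shown here on this aryl group each replaced the whole group, whereas here a single substituent changes at one place, meta to a large group: in this assay, nitro in place of chloro gives a 17-fold higher number from compound 3 to compound 4 (1.23 log units; beyond the scatter) and is larger than either of those earlier replacements. Going from either alkoxyphenyl compound to the 3-nitrophenyl group widens the gap further, with a 120-fold higher number from compound 1 to compound 4 (2.08 log units; beyond the scatter) and a 120-fold higher number from compound 2 to compound 4 (2.08 log units; beyond the scatter) in this set, so the aryl group on the amine nitrogen spans a wide range of numbers while the rest of the structure stays the same. No measured evidence here bears on the reason for the difference between nitro and chloro.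

As far as these compounds go, whether another group at this place, such as an amine or a nitrile, would fall nearer compound 3 or compound 4 remains open. Also open, from the compounds shown here alone, is whether the change from chloro to nitro would have a similar size elsewhere on the ring.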